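This account rests on a few compounds, and the source may have more. Where it says the series, first, only, none or still open, it means among the compounds named here.

Compound 1 `CNC(=O)c1cc(Oc2ccc(NC(=O)c3cc4cccnc4n(-c4ccccc4F)c3=O)cc2)ccn1` is the reference point. In a functional assay on A549 cells (Homo sapiens) for antiproliferative activity, read by MTT assay, with a stated time of 72 h (on this read-out higher numbers stand for weaker inhibition and lower numbers for stronger inhibition), compound 1 gives 610 nM, which is the lowest of the three numbers available. Two related compounds carry a different group on the same aromatic nitrogen of the shared core. Compound 2 `CNC(=O)c1cc(Oc2ccc(NC(=O)c3cc4cccnc4n(-c4ccc(OC)cc4)c3=O)cc2)ccn1` gives 3110 nM in this assay, and compound 3 `CNC(=O)c1cc(Oc2ccc(NC(=O)c3cc4cccnc4n(-c4ccc(C(F)(F)F)cc4Cl)c3=O)cc2)ccn1` gives 2090 nM. Each of these replacements raised the number beyond the scatter: a 5.1-fold higher number from compound 1 to compound 2 (0.71 log units; beyond the scatter) and a 3.4-fold higher number from compound 1 to compound 3 (0.53 log units; beyond the scatter). Compound 2 and compound 3 lie within the scatter of each other, a 1.5-fold lower number from compound 2 to compound 3 (0.17 log units; within the scatter).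

Compound 4 `CNC(=O)c1cc(Oc2ccc(NC(=O)c3cc4cccnc4n(-c4ccc(F)c(Cl)c4)c3=O)cc2)ccn1` has not yet been measured in this assay. It differs from compound 1 in one place: 3-chloro-4-fluorophenyl in place of 2-fluorophenyl on an aromatic nitrogen. Within the data shown here, both measured steps that swapped the 2-fluorophenyl of compound 1 for another group raised the number, so a rise is the more likely direction here, although only two such steps exist and neither of them carries a 3-chloro-4-fluorophenyl, so the size is uncertain. The step is expected to be modest: a 2.5-fold higher number from compound 1 to compound 4 (0.39 log units; beyond the scatter). On that basis compound 4 is estimated at 1500 nM, with a range from 600 nM to 4000 nM.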

Compound 4, half-maximal inhibitory concentration: 1560 nM
Compound 4: the middle estimate sits 1.0-fold (0.02 log units) below what was measured; low and high end bracket the measured number.
By their numbers in this assay, from the lowest: compound 1; then compounds 4, 3 and 2 (each within the scatter of the next).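

With the 3-chloro-4-fluorophenyl group, a third replacement of the 2-fluorophenyl on this aromatic nitrogen gives in this assay a 2.6-fold higher number from compound 1 to compound 4 (0.41 log units; beyond the scatter), in the same direction as the two earlier replacements, and since compound 4 also carries a fluorine on this ring, the presence of a fluorine alone does not hold the number at the level of compound 1. Compound 4 also sits level with the other two replacements, with a 1.3-fold lower number from compound 3 to compound 4 (0.13 log units; within the scatter) and a 2.0-fold lower number from compound 2 to compound 4 (0.30 log units; within the scatter) both within the scatter, so these three differently substituted rings cannot be told apart in this assay, and among the four compounds only compound 1 stands apart from the rest. No measurement at hand accounts for this result.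

A plain phenyl, a 2-chlorophenyl or a 3-fluorophenyl on this nitrogen would help to show whether the edge of compound 1 is tied to the 2-fluorophenyl itself. Also open, on these data alone, is how a cyclopropyl, or a phenyl bearing an amine or a carboxylic acid, would compare with compound 1 at 610 nM.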